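This account rests on a few compounds, and the source may have more. Where it says the series, first, only, none or still open, it means among the compounds named here.

Three compounds built on the same core differ only in the group attached to an oxygen on a saturated carbon. Compound 1 `CC(C)=CC[C@@H](OC(=O)C1CCOC1)C1=CC(=O)c2c(O)ccc(O)c2C1=O` carries an (oxolan-3-yl)carbonyl there, and in a functional assay on HeLa cells (Homo sapiens) for cytotoxicity, read by MTT assay (a higher number here means a weaker inhibitor, a lower number a stronger inhibitor), compound 1 gives 73500 nM. Compound 2 `CCCC(C)(O)CC(=O)O[C@H](CC=C(C)C)C1=CC(=O)c2c(O)ccc(O)c2C1=O` carries a (2-hydroxy-2-methylpentyl)carbonyl, and in this assay compound 2 gives 72000 nM. Compound 3 `COCCO[C@H](CC=C(C)C)C1=CC(=O)c2c(O)ccc(O)c2C1=O` carries a 2-methoxyethyl, and in this assay compound 3 gives 62400 nM, the lowest number of the three, though all three sit within the scatter of one another and cannot be told apart. Compound 4 `CCC(O)CO[C@H](CC=C(C)C)C1=CC(=O)c2c(O)ccc(O)c2C1=O` is compound 3 altered at that chain: 1-hydroxypropyl in place of methoxymethyl on a saturated chain carbon bound to an oxygen on a saturated carbon. For the measured compounds named here, the steps that bear on this are a 1.2-fold lower number from compound 1 to compound 3 (0.07 log units; within the scatter) and a 1.2-fold lower number from compound 2 to compound 3 (0.06 log units; within the scatter), both changes at the same oxygen, and both gave nothing beyond the scatter even though they swapped much larger groups than the present one. Exchanging one small chain for another at the same place is therefore expected to give no step beyond the scatter, a 1.0-fold lower number from compound 3 to compound 4 (0.00 log units; within the scatter). Compound 4 is expected to give 62000 nM, within 31000 nM to 124000 nM.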

Compound 4, half-maximal inhibitory concentration: 28700 nM
The estimate for compound 4 lay 2.2-fold (0.33 log units) above the measured number; the whole stated range lies above it.
By their numbers in this assay, from the lowest: compound 4; then compounds 3, 2 and 1 (each within the scatter of the next).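

Unlike the large swaps before it, this small change at the oxygen on a saturated carbon moves the number beyond the scatter: 2-hydroxybutyl gives a 2.2-fold lower number from compound 3 to compound 4 (0.34 log units; beyond the scatter), and it also separates compound 4 from the two carbonyl-linked compounds, with a 2.5-fold lower number from compound 2 to compound 4 (0.40 log units; beyond the scatter) and a 2.6-fold lower number from compound 1 to compound 4 (0.41 log units; beyond the scatter). The entering 1-hydroxypropyl brings a hydrogen-bond donor that the leaving methoxymethyl lacks, but a hydroxyl alone does not mark out the lower numbers, since compound 2 also carries one and stays within the scatter of compound 1 and compound 3. Nothing available explains this step.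

The hydroxyl and the added carbon arrive together, so the compounds shown cannot separate their contributions. Going by these compounds, whether an amine in place of that hydroxyl, or a longer chain, would lower the number further also remains open.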